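The source may report more compounds than this note shows. Statements on the series, on what has been measured and on what is new or still open speak of the compounds shown alone.

In a functional assay on PC-3 cells (Homo sapiens) for cytotoxicity, read by MTT assay, with a stated time of 72 h (on this read-out higher numbers stand for lower toxicity in this test and lower numbers for higher toxicity in this test), compound 1 `CS/C(=N\C(=O)c1ccco1)NC(=O)c1ccco1` gives > 100000 nM, a limit of the assay rather than a number. Compound 2 `C[Se]/C(=N\C(=O)c1cccs1)NC(=O)c1cccs1` likewise reaches only the limit, at > 100000 nM. Compound 3 `O=C(/N=C(/NC(=O)c1cc(-c2ccccc2)nc2ccccc12)[Se]Cc1ccccc1)c1cc(-c2ccccc2)nc2ccccc12` also sits at the limit, at > 100000 nM. All three values thus rest on (the limit of > 100000 nM in this assay, at which 3 of the 3 values shown sit), so compound 3 stands nowhere apart from the other two in this assay. Compound 4 `C[Se]/C(=N\C(=O)c1cc(-c2ccccc2)nc2ccccc12)NC(=O)c1cc(-c2ccccc2)nc2ccccc12` differs from compound 3 by hydrogen in place of phenyl on a saturated chain carbon bound to a selenium atom. Within the data shown here, with no step between measured compounds to draw on, the step that the limit leaves unreadable from compound 3 to compound 4 is expected to be none beyond the scatter. Compound 4 is therefore estimated at about 150000 nM in this assay, within 50000 nM to 500000 nM, most likely reported again only as a limit.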

Compound 4, concentration lethal to 50% of the cells: > 100000 nM
Compound 4: no number, only a limit; the forecaster's own chance of this, stated with the estimate: 90%; the middle value does not contradict the limit.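

Among these compounds, compound 3 and compound 4 both rest on a limit rather than a number, so no step between them can be read: the limit of > 100000 nM in this assay, at which 4 of the 4 values shown sit. In this assay the compounds shown leave open which change, if any, would give a measured value.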